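Benzamide ring change in a sulfonamide-linked benzamide series

The source may hold more compounds than are shown below. What is called first, only, known or untested is meant among the compounds shown, and "the series" means these compounds.

Compound 1 `O=C(NCc1ccc(CNS(=O)(=O)c2ccccc2)cc1)c1c(Cl)cc(Cl)cc1Cl` is measured in an assay on MDA-MB-231 cells for binding affinity to C-X-C chemokine receptor type 4 (Homo sapiens), read by immunofluorescence and microscopy, with stated times of 10 min and 30 min (a lower number here means that less compound is needed, a higher number that more compound is needed for the effect), at 10 nM. Among the measured compounds shown here, its single measured neighbour, compound 2 `Cc1ccc(S(=O)(=O)NCc2ccc(CNC(=O)c3c(Cl)cc(Cl)cc3Cl)cc2)cc1`, gives 10 nM in this assay, and the step of no change at the digits printed from compound 1 to compound 2 (within the scatter) shows that methyl in place of hydrogen on an aromatic carbon leaves the read-out unchanged within the scatter. For the measured compounds named here, compound 1 thus stands level with compound 2 at the digits printed, and the series so far holds no step that touches the carbonyl-side ring.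

Compound 3 `O=C(NCc1ccc(CNS(=O)(=O)c2ccccc2)cc1)c1ccc(Cl)cc1` differs from compound 1 in 4-chlorophenyl in place of 2,4,6-trichlorophenyl on a carbonyl carbon. Going by the values given here, no measured step bears on this change, since the only one in hand lies on the sulfonamide ring, so the size of the step cannot be read from the data. A shift beyond the scatter is thought possible; a modest loss of potency is expected, the estimated step being a 4.0-fold higher number from compound 1 to compound 3 (0.60 log units; beyond the scatter). Compound 3 is therefore expected at 40 nM, within 10 nM to 250 nM.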

Compound 3, effective concentration (reported as EC, without a stated level of effect): 100 nM
Compound 3: the middle estimate sits 2.5-fold (0.40 log units) below what was measured; measured number inside the range.
By their numbers in this assay, from the lowest: compounds 1 and 2 (each within the scatter of the next); then compound 3.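

Among the compounds shown here, the carbonyl-side ring is the first place where a change moves the read-out beyond the scatter: in this assay the replacement of 2,4,6-trichlorophenyl by 4-chlorophenyl gives a 10-fold higher number from compound 1 to compound 3 (1.00 log units; beyond the scatter), whereas the methyl on the sulfonamide ring gave no change at the digits printed from compound 1 to compound 2 (within the scatter). The change goes from the 2,4,6-trichlorophenyl group to the 4-chlorophenyl group in a single step, so the chlorines that leave cannot be told apart in their share of the step. No measured data in hand account for the size of this step.

The compounds shown leave open how an unsubstituted phenyl, a pyridine ring or an aminophenyl group on the carbonyl carbon compares with the two chlorinated rings. They also leave open whether the step from 2,4,6-trichlorophenyl to 4-chlorophenyl has the same size with the methyl-bearing sulfonamide ring of compound 2.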